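Opening the ring of compound 3

The source may hold more compounds than are shown below. What is called first, only, known or untested is meant among the compounds shown, and "the series" means these compounds.

Values measured in a functional assay on TMD8 cells (Homo sapiens) for cytotoxicity, read by CCK-8 assay, with a stated time of 72 h (on this read-out lower numbers stand for stronger inhibition and higher numbers for weaker inhibition), are as follows
- Compound 1 `Cn1cc(NC(=O)c2ncn3ccc(N4CCC[C@@H](N)C4)nc23)c(C(F)F)n1` gives > 50000 nM as a limit of the assay, not a number
- Compound 2 `Cn1cc(NC(=O)c2cnc3ccc(N[C@H]4CCCNC4)nn23)c(C(F)F)n1` gives 22300 nM here
- Compound 3 `Cn1cc(NC(=O)c2cnc3ccc(N[C@@H]4CCNC4)nn23)c(C(F)F)n1` gives 8300 nM here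

Compound 3 has the lowest of these values. The next compound, compound 4 `Cn1cc(NC(=O)c2cnc3ccc(NCCN)nn23)c(C(F)F)n1`, brings this change: 2-aminoethyl in place of pyrrolidin-3-yl on a nitrogen on an aromatic ring. Within the data shown here, only one measured step bears on it, and only loosely, since it swapped one ring for a smaller ring rather than removing the ring: a 2.7-fold lower number from compound 2 to compound 3 (0.43 log units; beyond the scatter). With so modest a guide, no step beyond the scatter is expected in this assay and the uncertainty stays wide. The expected change is a 1.0-fold lower number from compound 3 to compound 4 (0.02 log units; within the scatter) here. Compound 4 is estimated at 8000 nM (range 2000 nM to 32000 nM).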

Compound 4, half-maximal inhibitory concentration: 17700 nM
Compound 4: the middle estimate sits 2.2-fold (0.34 log units) below what was measured, within the range that was stated.
By their numbers in this assay, from the lowest: compound 3; then compounds 4 and 2 (each within the scatter of the next). At a limit, above all of these: compound 1.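

In this assay, replacing the pyrrolidin-3-yl ring with the open 2-aminoethyl chain on this nitrogen still leaves a measurable, though modest, change (a 2.1-fold higher number from compound 3 to compound 4 (0.33 log units; beyond the scatter)). The same chain cannot be separated from the larger piperidin-3-yl ring (a 1.3-fold lower number from compound 2 to compound 4 (0.10 log units; within the scatter)), so a ring is not needed here to match compound 2, while only compound 3 stands apart from compound 4. Nothing measured here explains either step.

Going by these compounds, whether a longer chain such as 3-aminopropyl would behave similarly remains open. So does the effect of ending the chain in a carboxylic acid instead of an amine.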